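Fluorine for chlorine on the pendant phenyl of a nitroimidazopyridine

The source may report more compounds than this note shows. Statements on the series, on what has been measured and on what is new or still open speak of the compounds shown alone.

Compound 1 `O=[N+]([O-])c1c(CS(=O)(=O)c2ccccc2)nc2c(-c3ccc(Cl)cc3)cc(Cl)cn12`: in an ADME assay on HepG2 cells (Homo sapiens) for cytotoxicity, read by MTT assay, with a stated time of 72 h (on this read-out higher numbers stand for lower toxicity in this test and lower numbers for higher toxicity in this test), compound 1 gives > 3900 nM, which is a limit of the assay and not a number.
Compound 2 `CCN(CC)c1ccc(-c2cc(Cl)cn3c([N+](=O)[O-])c(CS(=O)(=O)c4ccccc4)nc23)cc1`: in this assay compound 2 gives > 15600 nM, also a limit.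
Compound 3 `O=[N+]([O-])c1c(CS(=O)(=O)c2ccccc2)nc2c(-c3cccc(CO)c3)cc(Cl)cn12`: in this assay compound 3 gives > 25000 nM, also a limit.

Compound 1 stands only at a limit, so its place among the three cannot be read. The steps a step that the two limits leave unreadable from compound 1 to compound 2, a step that the two limits leave unreadable from compound 1 to compound 3 and a step that the two limits leave unreadable from compound 2 to compound 3 are all unreadable, because every value sits at a limit, as the limit of > 3900 nM in this assay, at which 1 of the 3 values shown sits, the limit of > 15600 nM in this assay, at which 1 of the 3 values shown sits, and the limit of > 25000 nM in this assay, at which 1 of the 3 values shown sits, show. Compound 4 `O=[N+]([O-])c1c(CS(=O)(=O)c2ccccc2)nc2c(-c3cccc(F)c3)cc(Cl)cn12` differs from compound 1 in one place: 3-fluorophenyl in place of 4-chlorophenyl on an aromatic carbon. Going by the values given here, none of the measured steps can be read in size, and the closest one, from compound 1 to compound 3, swaps the same 4-chlorophenyl yet gives a limit at both ends. The expectation is therefore no toxicity beyond the scatter and most likely another limit. Compound 4 is estimated at 20000 nM, with a range from 4000 nM to 100000 nM. The step that the limit leaves unreadable from compound 1 to compound 4 is the expected size, given that compound 1 shows only > 3900 nM.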

Compound 4, half-maximal cytotoxic concentration: > 12500 nM
Compound 4 ended at the assay's limit; the forecaster's own chance of this, stated with the estimate: 85%; the middle value lies beyond the limit too.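

In this assay, going by these compounds alone, compound 4 stays at a limit, as do compound 1, compound 2 and compound 3, so no step between compound 4 and these three can be read in size. The compounds shown leave open whether 3-fluorophenyl and 4-chlorophenyl differ at all in toxicity.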